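Notes on the amino substituent series, compound 3 pending

A few compounds are considered here, and "the series" means these few. Any claim that something is new, unique, unknown or untested is made for them only; others in the source may bear on it.

Measured so far:
compound 1 `OCCCNc1nc(-c2ccccc2)nc2c1nnn2Cc1ccccc1` — 21400000 nM
compound 2 `CCNc1nc(-c2ccccc2)nc2c1nnn2Cc1ccccc1` — 91000000 nM

Both numbers come from an assay on isolated protein for binding affinity to adenosine receptor A1 (Bos taurus); a higher number here means a weaker inhibitor, a lower number a stronger inhibitor. In this assay compound 1 gives 21400000 nM. In this assay compound 2 gives 91000000 nM, the higher of the two numbers. Going by the values given here, the only measured step, a 4.3-fold higher number from compound 1 to compound 2 (0.63 log units; beyond the scatter), is modest and lies beyond the scatter.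

Compound 3 `c1ccc(Cn2nnc3c(NC4CCC4)nc(-c4ccccc4)nc32)cc1` is not yet measured. It differs from compound 2 by cyclobutyl in place of ethyl on a nitrogen on an aromatic ring. Among the compounds with values here, the one known step concerns the group on the same nitrogen on the aromatic ring, but it removes a hydroxymethyl from a chain rather than exchanging ethyl for cyclobutyl, so it bears on the change only loosely: it shows that altering what sits on this nitrogen shifts the number modestly, without fixing a direction for the present change. Nothing in the two values speaks for a large step either way.

The expectation for compound 3 is therefore a step near the scatter, leaning slightly to a lower number, a 1.5-fold lower number from compound 2 to compound 3 (0.18 log units; within the scatter). Compound 3 is estimated at 60000000 nM, with a range from 15000000 nM to 250000000 nM.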

Compound 3, inhibition constant: 5000000 nM
For compound 3 the middle estimate is 12-fold (1.08 log units) above the measured one, outside the stated range (below it).
By their numbers in this assay, from the lowest: compound 3; then compound 1; then compound 2.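

In this assay, the change at the nitrogen on an aromatic ring gives an 18-fold lower number from compound 2 to compound 3 (1.26 log units; beyond the scatter), showing that this position can produce a large step and not only the modest one seen earlier. The exchange of ethyl for cyclobutyl is therefore far from neutral here, even though neither group has a hydrogen-bond donor or acceptor. Cyclobutyl also compares favourably with 3-hydroxypropyl, with a 4.3-fold lower number from compound 1 to compound 3 (0.63 log units; beyond the scatter), so compound 3 has the lowest number of the three and the lowest number at this position does not depend on a hydroxyl group. The data at hand offer no independent measurement that accounts for these steps.

Compound 3 differs from compound 2 in both carbon count and the presence of a ring, so the compounds shown do not separate these two changes; an open-chain butyl group would bear on that question, and cyclopropyl or cyclopentyl on the effect of ring size. Also open, on these data alone, is how a hydroxyl group or an amine carried on the cyclobutyl ring would alter the number in this assay.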